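The source may report more compounds than this note shows. Statements on the series, on what has been measured and on what is new or still open speak of the compounds shown alone.

In a physicochemical assay for solubility, at pH 7.4 (on this read-out lower numbers stand for lower solubility and higher numbers for higher solubility), the measured compounds stand as follows:

Compound 1, `Cc1cc(NC(=O)Nc2ccc(F)cc2)c2ccccc2n1`: 3700 nM
Compound 2, `Cc1cc(NC(=O)Nc2cccc(F)c2)c2ccccc2n1`: 100 nM
Compound 3, `Cc1cc(NC(=O)Nc2cc(F)cc(F)c2)c2ccccc2n1`: 300 nM

Compound 1 and compound 2 are built from the same atoms joined differently; the difference is 4-fluorophenyl in place of 3-fluorophenyl on an amide-type nitrogen. In this assay this gives a 37-fold lower number from compound 1 to compound 2 (1.57 log units; beyond the scatter), so compound 1 holds the highest number of the three. From compound 2 to compound 3 the change is fluoro in place of hydrogen on an aromatic carbon, and in this assay it gives a 3.0-fold higher number from compound 2 to compound 3 (0.48 log units; beyond the scatter).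

Compound 4, `Cc1cc(NC(=O)Nc2ccc(F)cc2F)c2ccccc2n1`, has not yet been measured. It differs from compound 1 by fluoro in place of hydrogen on an aromatic carbon. This is the same kind of change as that from compound 2 to compound 3, but not the same: in compound 3 the entering fluoro sits meta to a fluoro group and meta to a large group, whereas in compound 4 it sits ortho to a large group and meta to a fluoro group. For compound 4 a step of a 2.2-fold higher number from compound 1 to compound 4 (0.33 log units; beyond the scatter) in this assay is expected, resting on the step from compound 2 to compound 3, a 3.0-fold higher number from compound 2 to compound 3 (0.48 log units; beyond the scatter), with the changed surroundings widening the uncertainty. Compound 4 is therefore estimated at 8000 nM, between 2500 nM and 25000 nM.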

Compound 4, solubility: 3000 nM
For compound 4 the middle estimate is 2.7-fold (0.43 log units) above the measured one, and the stated range covers the measured number.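

In this assay fluoro in place of hydrogen on an aromatic carbon gives a 1.2-fold lower number from compound 1 to compound 4 (0.09 log units; within the scatter) and no step beyond the scatter, whereas the same kind of change gave a 3.0-fold higher number from compound 2 to compound 3 (0.48 log units; beyond the scatter) in its earlier setting, so in these two cases the step did not carry over from one compound to the other. That is only two instances, and the entering fluoro stands in different surroundings in each, in compound 4 ortho to a large group and meta to a fluoro group, so the pair does not show whether the surroundings or the starting compound decide the size of the step, nor how the change would read elsewhere in the series. Nothing available here bears on why the two steps differ.

The compounds shown carry only fluoro on that aromatic ring. As far as these compounds go, what a chloro group, a methoxy group or an amine would give on the same aromatic carbon remains open, as does any change to the shared core.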